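This account rests on a few compounds, and the source may have more. Where it says the series, first, only, none or still open, it means among the compounds named here.

Measured so far:
Compound 1, `N#CC1=C(N)Oc2c(N)cc3nc4ccccc4nc3c2C12C(=O)N(Cc1cnnn1-c1ccc(Cl)cc1)c1ccccc12`: > 50000 nM in an ADME assay on HUVEC cells (Homo sapiens) for antiproliferative activity, read by MTT assay, with a stated time of 48 h (on this read-out higher numbers stand for weaker inhibition and lower numbers for stronger inhibition), a limit of the assay rather than a number.
Compound 2, `CCc1cccc(C)c1-n1nncc1CN1C(=O)C2(C(C#N)=C(N)Oc3c(N)cc4nc5ccccc5nc4c32)c2ccccc21`: > 50000 nM in this assay, again only a limit.
Compound 3, `COc1ccc(OC)c(-n2nncc2CN2C(=O)C3(C(C#N)=C(N)Oc4c(N)cc5nc6ccccc6nc5c43)c3ccccc32)c1`: > 50000 nM in this assay, again only a limit.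

Compound 3 therefore stands nowhere in particular on the numbers shown: all three values sit at the limit of > 50000 nM in this assay, at which 3 of the 3 values shown sit, so none of the steps among them can be read. The step from compound 1 to compound 2 is a step that the two limits leave unreadable from compound 1 to compound 2, the step from compound 1 to compound 3 is a step that the two limits leave unreadable from compound 1 to compound 3, and the step from compound 2 to compound 3 is a step that the two limits leave unreadable from compound 2 to compound 3.

Compound 4, `Cc1ccc(Cl)cc1-n1nncc1CN1C(=O)C2(C(C#N)=C(N)Oc3c(N)cc4nc5ccccc5nc4c32)c2ccccc21`, differs from compound 3 in one place: 5-chloro-2-methylphenyl in place of 2,5-dimethoxyphenyl on an aromatic nitrogen. Every measured change at this position, the 4-chlorophenyl, the 2-ethyl-6-methylphenyl and the 2,5-dimethoxyphenyl, has left the value at the limit, so no size or direction of step can be taken from them. The expected step from compound 3 to compound 4 is accordingly a number no higher from compound 3 to compound 4 (the limit leaves the size open), with the likeliest outcome that compound 4 also reaches only a limit. The estimate for compound 4 in this assay is 50000 nM, between 20000 nM and 100000 nM.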

Compound 4, half-maximal inhibitory concentration: > 50000 nM
Compound 4: only a limit was reported (the forecaster's own chance of this, stated with the estimate: 85%); the middle value sits exactly at the limit.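

Compound 4 joins compound 1, compound 2 and compound 3 at a limit, so no step among them can be read: the limit of > 50000 nM in this assay, at which 4 of the 4 values shown sit.

The compounds shown leave open whether any aryl group at this position gives a measurable value in this assay.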